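This account rests on a few compounds, and the source may have more. Where it says the series, first, only, none or still open, it means among the compounds named here.

Compound 1 `Nc1sc2c(c1C(=O)NCc1ccccc1)CCN(Cc1ccccc1)C2` was tested in an in vitro assay on CHOk1 cells with adenosine receptor A1 (Homo sapiens) as the target (a lower number here means that less compound is needed, a higher number that more compound is needed for the effect), and gave 13100 nM. Its one companion, compound 2 `Nc1sc2c(c1C(=O)NCc1cccc(C(F)(F)F)c1)CCN(Cc1ccccc1)C2`, gave 15500 nM in this assay; the two numbers sit close together, and the step from compound 1 to compound 2 a 1.2-fold higher number from compound 1 to compound 2 (0.07 log units; within the scatter) is a trifluoromethyl in place of hydrogen on an aromatic carbon. On these two numbers compound 1 has the lower one, within the scatter of compound 2.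

Compound 3 `CN1CCc2c(sc(N)c2C(=O)NCc2ccccc2)C1` differs from compound 1 by hydrogen in place of phenyl on a saturated chain carbon bound to an amine nitrogen in a ring. For the measured compounds named here, no measured step touches the benzyl on the ring nitrogen; the only measured step, from compound 1 to compound 2, concerns the other benzyl and stayed within the scatter, so it gives little guidance here. Removing a whole phenyl is a larger change than that, and the expectation is for a step of about a 1.9-fold higher number from compound 1 to compound 3 (0.28 log units; within the scatter), more likely toward a higher number. Compound 3 is therefore estimated at 25000 nM, within a range from 6000 nM to 90000 nM.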

Compound 3, half-maximal effective concentration: 12000 nM
Estimate against measurement, compound 3: 2.1-fold (0.32 log units) above; measured number inside the range.
By their numbers in this assay, from the lowest: compounds 3, 1 and 2 (each within the scatter of the next).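

Replacing the benzyl on the ring nitrogen with methyl removes a whole phenyl, six carbon atoms in one aromatic ring, yet the step is a 1.1-fold lower number from compound 1 to compound 3 (0.04 log units; within the scatter). This shows that, between these two compounds, the phenyl at this place can go without any change beyond the scatter. The change is far larger than the earlier trifluoromethyl swap on the other benzyl, and it is just as flat in this measurement. Nothing measured here explains this result.

Still open, going by these compounds, is whether the ring nitrogen would give a similar number with hydrogen, an ethyl or longer chain, or an acetyl group on it. On these data alone, the benzyl on the amide also remains untested by any larger change, such as replacing it with methyl or a cyclohexylmethyl group.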